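A hydroxyl added to the chain of compound 1

The source may hold more compounds than are shown below. What is called first, only, known or untested is meant among the compounds shown, and "the series" means these compounds.

Compound 1 `CCn1cnc2ncnc(N)c21` was examined in a functional assay on CHO cells for antagonist activity at adenosine receptor A2b (Homo sapiens); a lower number here means a stronger inhibitor, a higher number a weaker inhibitor. In this assay compound 1 reaches only a limit, > 30000 nM. Compound 2 `CC(C)n1cnc2ncnc(N)c21` likewise gives only the limit > 30000 nM. Compound 3 `CCC(C)n1cnc2ncnc(N)c21` also stops at the limit > 30000 nM. The steps a step that the two limits leave unreadable from compound 1 to compound 2, a step that the two limits leave unreadable from compound 1 to compound 3 and a step that the two limits leave unreadable from compound 2 to compound 3 therefore carry no readable size because of the limit of > 30000 nM in this assay, at which 3 of the 3 values shown sit. Compound 4 `CC(O)Cn1cnc2ncnc(N)c21` has not yet been measured; it differs from compound 1 by 1-hydroxyethyl in place of methyl on a saturated chain carbon bound to an aromatic nitrogen. For the measured compounds named here, since none of the measured steps has a readable size, no direction can be drawn from them for this change. Compound 4 is expected to remain at or near the limit, with an estimated step that the limit leaves unreadable from compound 1 to compound 4. The estimate for compound 4 is 40000 nM, within 15000 nM to 100000 nM.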

Compound 4, inhibition constant: > 30000 nM
Compound 4 gave a limit, no number; the forecaster's own chance of this, stated with the estimate: 85%; the middle value does not contradict the limit.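

Compound 4 also stops at a limit, so its steps from compounds 1, 2 and 3 cannot be read: the limit of > 30000 nM in this assay, at which 4 of the 4 values shown sit. The compounds shown leave open whether any chain on the shared core gives a readable value in this assay at all.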